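Ester Replaced by Phenyl on the Piperidine Ring

The compounds below may be only part of what the source reports. "The series", "measured", "known", "first", "only" and "open" are said of these compounds alone.

Compound 1 `COc1cc2c(Nc3ccc(C#N)cc3)ncnc2cc1OCCCN(C)Cc1ccccc1`: in a functional assay on HepG2 cells (Homo sapiens) for antiproliferative activity, read by MTT assay, with a stated time of 72 h (a higher number here means a weaker inhibitor, a lower number a stronger inhibitor), compound 1 reaches only the limit > 100000 nM and gives no number.
Compound 2 `COc1cc2c(Nc3ccc(C#N)cc3)ncnc2cc1OCCCN1CCCCC1`: in this assay compound 2 gives 20700 nM.
Compound 3 `CCOC(=O)C1CCN(CCCOc2cc3ncnc(Nc4ccc(C#N)cc4)c3cc2OC)CC1`: in this assay compound 3 gives 57700 nM.

Within the data shown here, of the two numbers in this assay, compound 3 holds the higher one, its only neighbour being set by a 2.8-fold higher number from compound 2 to compound 3 (0.45 log units; beyond the scatter). Compound 1 stands apart, at the limit of > 100000 nM in this assay, at which 1 of the 3 values shown sits.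

Compound 4 `COc1cc2c(Nc3ccc(C#N)cc3)ncnc2cc1OCCCN1CCC(c2ccccc2)CC1` differs from compound 3 in one place: phenyl in place of ethoxycarbonyl on a saturated ring carbon. Among the measured compounds shown here, only one measured step touches that ring carbon, a 2.8-fold higher number from compound 2 to compound 3 (0.45 log units; beyond the scatter), which shows what placing the ester there did against the bare ring. The other two steps, an at least 4.8-fold lower number from compound 1 to compound 2 (0.68 log units; beyond the scatter) and an at least 1.7-fold lower number from compound 1 to compound 3 (0.23 log units; that floor lies within the scatter), concern the amine itself and say nothing about a phenyl on the ring. For the measured compounds named here, no measured step swaps an ester for an aromatic ring, so the direction is open. Compound 4 is therefore expected to move little from compound 3, with a 1.4-fold lower number from compound 3 to compound 4 (0.16 log units; within the scatter) falling within the scatter. Compound 4 is estimated at 40000 nM in this assay, with a range from 10000 nM to 150000 nM.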

Compound 4, half-maximal inhibitory concentration: 4610 nM
The estimate for compound 4 lay 8.7-fold (0.94 log units) above the measured number; the measured number lies below the stated range.
By their numbers in this assay, from the lowest: compound 4; then compound 2; then compound 3. At a limit, above all of these: compound 1.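

On the saturated ring carbon three ring bonds from the ring nitrogen, the outcome in this assay depends on the group placed there: ethoxycarbonyl gave a 2.8-fold higher number from compound 2 to compound 3 (0.45 log units; beyond the scatter), whereas phenyl gave a 4.5-fold lower number from compound 2 to compound 4 (0.65 log units; beyond the scatter), so this carbon is not simply a place where any addition to the bare piperidine costs activity. Among these compounds, exchanging one group for the other gives a 13-fold lower number from compound 3 to compound 4 (1.10 log units; beyond the scatter), a larger step than either group makes against hydrogen, and the first measured step at this carbon to lower the number. Set against the open-chain amine, the 4-phenylpiperidin-1-yl group gives an at least 21-fold lower number from compound 1 to compound 4 (1.33 log units; beyond the scatter), and that figure is a floor, as compound 1 is known only as a limit: the limit of > 100000 nM in this assay, at which 1 of the 4 values shown sits.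

The compounds shown leave open whether the lower number belongs to phenyl alone or would also be seen with a benzyl group, a pyridine ring, a carboxylic acid or an amine on the same ring carbon. They also leave open whether the step from ethoxycarbonyl to phenyl would keep its size with a longer chain between the oxygen and the piperidine nitrogen.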